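Chloro for fluoro on the aryl ring of compound 3

The source may hold more compounds than are shown below. What is called first, only, known or untested is meant among the compounds shown, and "the series" means these compounds.

Of the compounds shown here, three sharing one core have been tested in an ADME assay on microsomes from liver (Rattus norvegicus) for metabolic stability; on this read-out lower numbers stand for a shorter-lived compound and higher numbers for a longer-lived compound. Compound 1 `Nc1nc(NCCNc2ncc(-c3ncc[nH]3)c(-c3ccc(F)cc3F)n2)ccc1[N+](=O)[O-]` gives in this assay > 0.5 h, which is a limit of the assay rather than a number. Compound 2 `Nc1nc(NCCNc2ncc(-c3ncc[nH]3)c(-c3ccc(Cl)cc3F)n2)ccc1[N+](=O)[O-]` gives > 0.5 h, again a limit. Compound 3 `Nc1nc(NCCNc2ncc(-c3ncc[nH]3)c(-c3cc(F)c(Cl)cc3F)n2)ccc1[N+](=O)[O-]` gives > 0.5 h, also a limit. The steps between them are therefore a step that the two limits leave unreadable from compound 1 to compound 2, a step that the two limits leave unreadable from compound 1 to compound 3 and a step that the two limits leave unreadable from compound 2 to compound 3. What the three share is the limit of > 0.5 h in this assay, at which 3 of the 3 values shown sit.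

Compound 4 `Nc1nc(NCCNc2ncc(-c3ncc[nH]3)c(-c3cc(F)c(Cl)cc3Cl)n2)ccc1[N+](=O)[O-]` has not yet been measured. It differs from compound 3 by chloro in place of fluoro on an aromatic carbon. The same kind of change joins the two measured compounds: compound 2 differs from compound 1 by chloro in place of fluoro on an aromatic carbon, and that step in this assay is a step that the two limits leave unreadable from compound 1 to compound 2. The two cores differ by 4-chloro-2,5-difluorophenyl in place of 2,4-difluorophenyl on an aromatic carbon. The surroundings are not the same: in compound 1 the exchanged atom sits meta to a fluoro group and para to a large group, whereas in compound 3 it sits ortho to a large group, meta to a chloro group and para to a fluoro group, so the change is of the same kind, not the same.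

For compound 4 in this assay an expected step that the limit leaves unreadable from compound 3 to compound 4 is set down, resting on the fact that compounds 1, 2 and 3 all sit at the limit of > 0.5 h in this assay, at which 3 of the 3 values shown sit. Compound 4 is thus estimated at 0.8 h, expected to lie between 0.4 h and 2 h.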

Compound 4, half-life: > 0.5 h
Compound 4: only a limit was reported; the forecaster's own chance of this, stated with the estimate: 70%; the middle value is on the limit's open side.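

In this assay compound 4 gives > 0.5 h, which is a limit of the assay and not a number. No step from compound 1, compound 2 or compound 3 to compound 4 can be read, and all four compounds share one result: the limit of > 0.5 h in this assay, at which 4 of the 4 values shown sit.

The compounds shown leave open what the actual half-life of each is, and so whether chloro in place of fluoro changes it at all in this assay.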